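Amino for hydrogen on the anilino ring of compound 1

The source may hold more compounds than are shown below. What is called first, only, known or untested is meant among the compounds shown, and "the series" means these compounds.

Measured in a functional assay on HL-60 cells (Homo sapiens) for cytotoxicity, read by MTT assay, with a stated time of 48 h; on this read-out lower numbers stand for stronger inhibition and higher numbers for weaker inhibition:
- compound 1 `Fc1cccc(-c2nc(Nc3ccccc3)c3cc(F)ccc3n2)c1` gives 48300 nM
- compound 2 `Fc1ccc(Nc2nc(-c3cccc(F)c3)nc3ccc(F)cc23)cc1` gives > 50000 nM, which is a limit of the assay and not a number
- compound 3 `Fc1cccc(-c2nc(Nc3ccccc3F)c3cc(F)ccc3n2)c1` gives > 50000 nM, also a limit of the assay and not a number

For the measured compounds named here, compound 1 therefore stands as the only compound with a number in this set; the other two sit at the limit of > 50000 nM in this assay, at which 2 of the 3 values shown sit. The steps of an at least 1.0-fold higher number from compound 1 to compound 2 (0.01 log units; that floor lies within the scatter) and an at least 1.0-fold higher number from compound 1 to compound 3 (0.01 log units; that floor lies within the scatter) both add fluoro in place of hydrogen on an aromatic carbon, and each reaches only a floor that lies within the scatter. The step that the two limits leave unreadable from compound 2 to compound 3 cannot be read at all.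

Compound 4 `Nc1ccc(Nc2nc(-c3cccc(F)c3)nc3ccc(F)cc23)cc1` is not yet measured. It differs from compound 1 by amino in place of hydrogen on an aromatic carbon. Going by the values given here, none of the measured steps concerns an amino group, so there is no direct guide; the fluoro steps to compound 2 and compound 3 show only that changes on these rings have not produced strong inhibition. For compound 4 a step of a 1.2-fold lower number from compound 1 to compound 4 (0.08 log units; within the scatter) is expected, that is, no change beyond the scatter, with a fair chance that only a limit is returned. The estimate for compound 4 is 40000 nM, ranging from 12000 nM to 120000 nM.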

Compound 4, half-maximal inhibitory concentration: > 50000 nM
Compound 4 was reported as a limit; the forecaster's own chance of this, stated with the estimate: 40%; middle value at least 1.2-fold (0.09 log units) away from the limit.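

In this assay compound 4 gives > 50000 nM, which is a limit of the assay and not a number. Placing an amino group on the anilino ring, para to a large group, gives an at least 1.0-fold higher number from compound 1 to compound 4 (0.01 log units; that floor lies within the scatter), so this small nitrogen substituent shows no sign of stronger inhibition, just as the fluoro changes showed none. The steps from compound 2 and from compound 3 to compound 4 cannot be read, so amino and fluoro cannot be ranked against each other, and the set now stands as follows: the limit of > 50000 nM in this assay, at which 3 of the 4 values shown sit.

From the compounds shown here alone, whether a hydroxyl group, a carboxylic acid or a longer chain such as aminoethyl on this ring would give a readable number remains open. So does whether a change elsewhere on the shared core would matter more.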